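Moving the Nitro Group on a Cyanoguanidine Series

A few compounds are considered here, and "the series" means these few. Any claim that something is new, unique, unknown or untested is made for them only; others in the source may bear on it.

- Compound 1 `N#CN(C(=N)NCCCCCOc1ccccc1)c1ccncc1` gives 270 nM
- Compound 2 `N#CN/C(=N\CCCCCCCOc1ccccc1)Nc1cccnc1` gives 360 nM
- Compound 3 `N#CN/C(=N\CCCCCCOc1ccccc1[N+](=O)[O-])Nc1ccncc1` gives 41 nM

All three compounds were tested in a functional assay on NCI-H460 cells (Homo sapiens) for antiproliferative activity (on this read-out lower numbers stand for stronger inhibition and higher numbers for weaker inhibition), and compound 3 has the lowest number at 41 nM in that set. Compound 1 and compound 2 both sit higher than compound 3, each by a margin beyond the usual scatter, which makes compound 3 the most potent of the three.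

Compound 4 `N#CN/C(=N\CCCCCCOc1ccc([N+](=O)[O-])cc1)Nc1ccncc1` has not yet been measured. Within the data shown here, it holds the same atoms as compound 3, joined differently, with 4-nitrophenyl in place of 2-nitrophenyl on an oxygen on a saturated carbon as the only change.

Among the measured compounds shown here, no two measured compounds differ in just one place, so the data offer no direct precedent for this move. The expectation therefore rests on compound 3 at 41 nM as the closest measured neighbour. The expected result is a 1.6-fold lower number from compound 3 to compound 4 (0.21 log units; within the scatter) and this estimated step stays within the scatter, so no clear shift in either direction is foreseen in this assay for now. For compound 4 the estimated value is 25 nM with an expected range from 6 nM to 100 nM as the likely span.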

Compound 4, half-maximal inhibitory concentration: 590 nM
The estimate for compound 4 lay 24-fold (1.37 log units) below the measured number; the measured number lies above the stated range.
By their numbers in this assay, from the lowest: compound 3; then compounds 1, 2 and 4 (each within the scatter of the next, the first and the last beyond it).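

In this assay, among these compounds, putting 4-nitrophenyl in place of 2-nitrophenyl on an oxygen on a saturated carbon gives a 14-fold higher number from compound 3 to compound 4 (1.16 log units; beyond the scatter), and this is the first comparison that isolates a single change. The two compounds hold the same atoms, and the groups that leave and enter match in every count, so this large step shows that the read-out at this position responds to how the nitrophenyl group is joined, not merely to which atoms are present. Nothing available bears on what lies behind the step, so its cause remains unknown.

The compounds shown leave open whether 2-nitrophenyl holds its advantage over 4-nitrophenyl only as a nitro-bearing group, or whether a nitrile, a carboxylic acid or an amine on the ring in place of the nitro group would separate the same two arrangements. They also leave open whether a step of this size would recur with a longer chain or a shorter chain joining the oxygen to the shared core, since this single pair carries only one chain.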